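Thiophene in Place of Acetylphenyl: An Expected Binding Value

The source may report more compounds than this note shows. Statements on the series, on what has been measured and on what is new or still open speak of the compounds shown alone.

Of the compounds shown here, two with a shared core have so far been measured in an assay on LM cells for displacement of a labelled ligand from Neuropeptide Y receptor type 5 (Homo sapiens); a lower number here means a stronger inhibitor, a higher number a weaker inhibitor. Compound 1 `Fc1ccc(C2(c3ccc(F)cc3)CNC(c3cccc(Br)c3)=N2)cc1` gives 4.8 nM in this assay, while compound 2 `CC(=O)c1cccc(C2=NC(c3ccc(F)cc3)(c3ccc(F)cc3)CN2)c1` gives 44 nM. For the measured compounds named here, the single step that connects them, acetyl in place of bromo on an aromatic carbon, is a 9.2-fold higher number from compound 1 to compound 2 (0.96 log units; beyond the scatter). Going by the values given here, compound 2 therefore stands at the higher of the two numbers, with compound 1 as its only neighbour.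

Compound 3 `Fc1ccc(C2(c3ccc(F)cc3)CNC(c3cccs3)=N2)cc1` has not yet been measured. It differs from compound 2 in one place: thiophen-2-yl in place of 3-acetylphenyl on a carbon with a double bond to nitrogen. Among the compounds with values here, no measured step covers this exact exchange. Within the data shown here, the one step that bears on the same position, a 9.2-fold higher number from compound 1 to compound 2 (0.96 log units; beyond the scatter), shows that swapping the group on that carbon shifts the number by a modest amount, and that compound 1 with its bromo group holds the lower value. Since a five-membered aromatic ring is new to the set, the expectation rests on that single step and is held loosely. Compound 3 is expected to give roughly 15 nM in this assay, with a plausible spread from 4 nM to 60 nM. The estimated step of a 2.9-fold lower number from compound 2 to compound 3 (0.47 log units; beyond the scatter) is thus expected to be a modest lowering rather than a large one.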

Compound 3, half-maximal inhibitory concentration: 54 nM
Beside the measured number, compound 3's estimate is 3.6-fold (0.56 log units) below it; the measured number falls inside the stated range.
By their numbers in this assay, from the lowest: compound 1; then compounds 2 and 3 (each within the scatter of the next).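

In this assay, the exchange of 3-acetylphenyl for thiophen-2-yl on the carbon with a double bond to nitrogen gives a 1.2-fold higher number from compound 2 to compound 3 (0.09 log units; within the scatter), so a five-membered aromatic ring of 5 heavy atoms and a six-membered aromatic ring group of 9 heavy atoms cannot be told apart at this position by this read-out. The earlier step had shown only that acetyl and bromo differ on the same phenyl ring, whereas the exchange of 3-bromophenyl for thiophen-2-yl gives an 11-fold higher number from compound 1 to compound 3 (1.05 log units; beyond the scatter), which leaves compound 1 as the only one of the three with the low number and shows that neither of the other two groups shares it. No measurement is at hand that would explain this pattern.

The compounds shown leave open whether the low number of compound 1 goes with the bromo group itself or with any 3-substituted phenyl of similar size, which an unsubstituted phenyl, a 3-chlorophenyl or a 3-methylphenyl at this carbon would help to separate. They also leave open whether a bromo group on the thiophene ring would bring the number down in the same way, and how an amine or a carboxylic acid on the phenyl ring would fare.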